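A few compounds are considered here, and "the series" means these few. Any claim that something is new, unique, unknown or untested is made for them only; others in the source may bear on it.

Four compounds built around a shared bicyclic core carrying a chloro group are compared in a functional assay on SK-OV-3 cells (Homo sapiens) for cytotoxicity, read by sulforhodamine B assay, with a stated time of 48 h; a lower number here means a stronger inhibitor of growth, a higher number a weaker inhibitor of growth. Compound 1, `Nc1nc(Cl)c2ncn(Cc3ccc(CCl)cc3)c2n1`, gives 30900 nM. Compound 3, `ClCc1ccc(Cn2cnc3c(Cl)nc(Cl)nc32)cc1`, gives 29500 nM. The two differ in one place, and the step of a 1.0-fold higher number from compound 3 to compound 1 (0.02 log units; within the scatter) is amino in place of chloro on an aromatic carbon, described as amino in place of chloro on an aromatic carbon. Compound 2, `ClCc1cccc(Cn2cnc3c(Cl)nc(Cl)nc32)c1`, has no result in this assay: its value is recorded as "not determined" (no result reported). Compound 2 and compound 3 are made of the same atoms joined differently; the difference between the two cores is not broken down here.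

Compound 4, `Nc1nc(Cl)c2ncn(Cc3cccc(CCl)c3)c2n1`, has not been measured. It stands to compound 2 as compound 1 stands to compound 3: the change from compound 2 to compound 4 is amino in place of chloro on an aromatic carbon, and the place description matches that of the change from compound 3 to compound 1 word for word, so it is the same change made on a differently joined core. Because the measured instance of this change, a 1.0-fold higher number from compound 3 to compound 1 (0.02 log units; within the scatter), lies within the usual scatter, the same step is expected to leave the value of compound 4 close to that of its chloro counterpart. Compound 2 offers no number to anchor this, so the expectation for compound 4 rests on compound 1 and compound 3 alone, and compound 4 is estimated to give 30000 nM, with a range from 10000 nM to 90000 nM.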

Compound 4, concentration for total growth inhibition: 67600 nM
Beside the measured number, compound 4's estimate is 2.3-fold (0.35 log units) below it; measured number inside the range.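

No new step can be read from compound 4: in this assay compound 4 gives 67600 nM but compound 2, its chloro counterpart, offers no number to set against it. The compounds shown leave open whether amino in place of chloro on an aromatic carbon acts on the core of compound 4 as it does on the core of compound 1. No evidence bears on this result.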